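The compounds below may be only part of what the source reports. "The series", "measured", "known", "first", "only" and "open" are said of these compounds alone.

The three measured compounds share one fused two-ring core. Compound 1 `CO[C@H]1CC=C2CCN(C)[C@H]2C1` carries a methyl on the ring nitrogen and a methyl on the oxygen, and in an assay on HEK293 cells for antagonist activity at Nicotinic acetylcholine receptor alpha-4/beta-2 (Mus musculus), read by FLIPR, using a membrane potential dye (on this read-out lower numbers stand for stronger inhibition and higher numbers for weaker inhibition), compound 1 gives 30000 nM. Compound 2 `CO[C@H]1CC=C2CCN[C@H]2C1` keeps the methyl on the oxygen but has hydrogen on the amine nitrogen in the ring; in this assay compound 2 gives 100000 nM. That exchange amounts to a 3.3-fold higher number from compound 1 to compound 2 (0.52 log units; beyond the scatter). Compound 3 `CN1CCC2=CC[C@H](O)C[C@@H]21` instead keeps the methyl on the nitrogen and has hydrogen on the oxygen. In this assay compound 3 reaches only > 100000 nM, which is a limit of the assay rather than a measured number. Compound 3 thus stands at the limit of > 100000 nM in this assay, at which 1 of the 3 values shown sits. The step that led there was an at least 3.3-fold higher number from compound 1 to compound 3 (0.52 log units; beyond the scatter).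

Compound 4 `O[C@H]1CC=C2CCN[C@H]2C1` takes compound 3 one step further: hydrogen in place of methyl on an amine nitrogen in a ring. For the measured compounds named here, the only measured step of this kind, a 3.3-fold higher number from compound 1 to compound 2 (0.52 log units; beyond the scatter), raised the number modestly, so in this assay a modest rise, or a change within the scatter, is expected here as well. Compound 3 already sits at the limit, and compound 4 is therefore expected to return a limit too, with an estimated step that the limit leaves unreadable from compound 3 to compound 4. The estimate for compound 4 is 300000 nM, in a range from 100000 nM to 1000000 nM.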

Compound 4, half-maximal inhibitory concentration: > 300000 nM
Compound 4 gave a limit, no number (the forecaster's own chance of this, stated with the estimate: 85%); the middle value sits exactly at the limit.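

Compound 3 and compound 4 both stand at limits, not at numbers, and the step between them cannot be read, so the compounds give no size for the methyl on the ring nitrogen once the oxygen carries hydrogen. The new information lies in the other step: with hydrogen already on the ring nitrogen, hydrogen in place of methyl on the oxygen still gives an at least 3.0-fold higher number from compound 2 to compound 4 (0.47 log units; beyond the scatter) in this assay. The loss of the methyl on the oxygen therefore goes with weaker inhibition whether the ring nitrogen carries methyl or hydrogen, so this finding no longer rests on a single pair: the same change on two cores in this assay, an at least 3.3-fold higher number (0.52 log units; beyond the scatter) from compound 1 to compound 3 and an at least 3.0-fold higher number (0.47 log units; beyond the scatter) from compound 2 to compound 4; the limit leaves it open whether they differ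

The compounds shown leave open how large the change on the oxygen really is, and whether the two steps differ in size, since each one ends at a limit. They also leave open how this assay would read a longer chain such as ethyl or propyl on the oxygen, or on the ring nitrogen, in place of methyl.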